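A few compounds are considered here, and "the series" means these few. Any claim that something is new, unique, unknown or untested is made for them only; others in the source may bear on it.

Among the compounds with values here, in an ADME assay on MDBK cells (Bos taurus) for cytotoxicity, read by MTT assay, with a stated time of 96 h (a lower number here means that less compound is tolerated, a higher number that more compound is tolerated), compound 3 `COc1ccc(-c2nc3cc(/C(C)=N/NC(N)=S)ccc3[nH]2)cc1` gives 13000 nM, the only true number in this small set. The other two results are limits. Compound 1 `COc1ccc(-c2nc3cc(C(C)O)ccc3[nH]2)c(OC)c1` reports only a limit, > 100000 nM. Compound 2 `COc1ccc(-c2nc3cc(/C(C)=N/O)ccc3[nH]2)c(OC)c1` also reports only a limit, > 100000 nM.

Compound 4 `COc1ccc(-c2nc3cc(/C(C)=N/NC(N)=S)ccc3[nH]2)c(OC)c1` keeps the group on the core of compound 3 and changes one position on the other ring: methoxy in place of hydrogen on an aromatic carbon, ortho to a large group and meta to a methoxy group (methoxy in place of hydrogen on an aromatic carbon).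

Within the data shown here, the only measured step, a step that the two limits leave unreadable from compound 1 to compound 2, offers little guidance. Both of its ends are limits, and it concerns a different group, not this methoxy. Compound 1 and compound 2 do carry the methoxy that compound 4 gains, yet both also lack the group shared by compound 3 and compound 4. Their limits therefore cannot be credited to the methoxy alone. Among the measured compounds shown here, with no measured step to size this change, only a modest shift towards more tolerated compound is expected, and nothing beyond the usual scatter. The expected step is a 1.4-fold higher number from compound 3 to compound 4 (0.14 log units; within the scatter) in this assay. For compound 4 the estimated value is 18000 nM, with an expected range of 6000 nM to 70000 nM.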

Compound 4, half-maximal cytotoxic concentration: > 100000 nM
Compound 4: only a limit was reported (the forecaster's own chance of this, stated with the estimate: 12%); middle value at least 5.5-fold (0.74 log units) away from the limit.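

In this assay, methoxy in place of hydrogen on an aromatic carbon, ortho to a large group and meta to a methoxy group, gives an at least 7.6-fold higher number from compound 3 to compound 4 (0.88 log units; beyond the scatter), so with the rest of the structure unchanged, this single position clearly affects how much compound the cells tolerate. Compound 4 reports only a limit, > 100000 nM. Within the data shown here, compound 1 and compound 2 also carry this methoxy but lack the group shared by compound 3 and compound 4, so this new pair is the first to show the methoxy as the only change.

One pair leaves open whether another group at this position, such as an ethoxy, a fluorine or an amine, would give a similar step, and whether the methoxy would have the same effect with a different group on the shared core. The steps from compound 1 and from compound 2 to compound 4 cannot be read, and how far the tolerated amount of compound 4 exceeds that of the others stays unknown because the values gather at one limit: the limit of > 100000 nM in this assay, at which 3 of the 4 values shown sit.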